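The compounds below may be only part of what the source reports. "The series", "measured", "known", "first", "only" and "open" are said of these compounds alone.

Measured so far in an ADME assay on RAW264.7 cells (Mus musculus) for cytotoxicity, read by MTT assay, with a stated time of 72 h; a lower number here means a stronger inhibitor, a higher number a weaker inhibitor:
- compound 1 `O=C(O)c1cn(C2CC2)c2cc(N3CCN(C(=O)CN4CCN(Cc5ccccc5)CC4)CC3)c(F)cc2c1=O`: 161000 nM
- compound 2 `O=C(O)c1cn(C2CC2)c2cc(N3CCN(C(=O)CN4CCN(C(c5ccccc5)c5ccccc5)CC4)CC3)c(F)cc2c1=O`: 96600 nM

Compound 2 gives the lowest of the two numbers recorded in this assay, but its separation from compound 1 is small: the step of a 1.7-fold lower number from compound 1 to compound 2 (0.22 log units; within the scatter) sits within the scatter, so the two compounds cannot be ordered against each other on the data shown.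

Compound 3 `CC(c1ccccc1)N1CCN(CC(=O)N2CCN(c3cc4c(cc3F)c(=O)c(C(=O)O)cn4C3CC3)CC2)CC1` is the next point in the series. Relative to compound 2 the change is methyl in place of phenyl on a saturated chain carbon bound to an amine nitrogen in a ring and an aromatic carbon. Going by the values given here, the only measured step touching this position is the one from compound 1 to compound 2, and it was within the scatter. Nothing here suggests that this position moves the number much in either direction, so no step beyond the scatter is expected from compound 2 to compound 3 in this assay.

The estimate for compound 3 is 130000 nM (range 60000 nM to 280000 nM), which implies an expected step of a 1.3-fold higher number from compound 2 to compound 3 (0.13 log units; within the scatter).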

Compound 3, half-maximal inhibitory concentration: 148000 nM
Estimate against measurement, compound 3: 1.1-fold (0.06 log units) below; low and high end bracket the measured number.
By their numbers in this assay, from the lowest: compounds 2, 3 and 1 (each within the scatter of the next).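

Methyl in place of phenyl gives a 1.5-fold higher number from compound 2 to compound 3 (0.19 log units; within the scatter) in this assay, and methyl in place of hydrogen gives a 1.1-fold lower number from compound 1 to compound 3 (0.04 log units; within the scatter) in the same assay. Going by these compounds alone, with the earlier step, this means that hydrogen, methyl and phenyl have now all been compared on the saturated chain carbon bound to an amine nitrogen in a ring and an aromatic carbon, and no pair among compounds 1, 2 and 3 separates beyond the scatter. No supporting data bear on why these numbers stay so close together.

The compounds shown leave open whether an amine or a carboxylic acid at this place, or a longer chain in place of methyl, would give a step beyond the scatter. They also leave open how this position behaves in any read-out other than this assay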